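A few compounds are considered here, and "the series" means these few. Any claim that something is new, unique, unknown or untested is made for them only; others in the source may bear on it.

Measured so far in an assay on isolated protein for inhibition of Group 10 secretory phospholipase A2 (Homo sapiens), with a stated time of 30 min; a higher number here means a weaker inhibitor, a lower number a stronger inhibitor:
compound 1 `NC(=O)c1cc(-c2ccccc2Cl)[nH]n1` gives 9330 nM
compound 2 `Cc1sc2ccccc2c1-c1cc(C(N)=O)nn1C` gives 851 nM
compound 3 `Cc1cc(-c2cc(C(N)=O)nn2C)c(C)s1` gives 851 nM

Compound 2 stands level with compound 3 at the digits shown, and the two together give the lowest numbers of the three; compound 1 gives a higher number, beyond the scatter from both. Compound 4 `Cc1sc2ccccc2c1-c1cc(C(N)=O)n[nH]1` differs from compound 2 by hydrogen in place of methyl on an aromatic nitrogen. Among the compounds with values here, no measured pair covers this change on its own; compound 1, the only other compound with hydrogen on that ring nitrogen, also carries a different group on the ring, so its number is not a guide by itself. A moderate step toward a higher number is expected, with a step within the scatter also plausible. The expected step is a 1.8-fold higher number from compound 2 to compound 4 (0.25 log units; within the scatter). Compound 4 is estimated at 1500 nM, with a range from 500 nM to 5000 nM.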

Compound 4, half-maximal inhibitory concentration: 174 nM
Beside the measured number, compound 4's estimate is 8.6-fold (0.94 log units) above it; the measured number lies below the stated range.
By their numbers in this assay, from the lowest: compound 4; then compounds 2 and 3 (each within the scatter of the next); then compound 1.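

In this assay hydrogen in place of methyl on the aromatic nitrogen brings a 4.9-fold lower number from compound 2 to compound 4 (0.69 log units; beyond the scatter) and gives the first single-change read on this position. The methyl is therefore not required for the level of compound 2, and this position responds to the change. No measured data bearing on the cause of this step are available.

Open, on these data alone, is whether ethyl or acetyl on that nitrogen would stand nearer to hydrogen or to methyl. Also open, as far as these compounds go, is whether the same change on the core of compound 3 gives a step of similar size.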